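Swapping the Amide Aryl Cap for a Thiazole

A few compounds are considered here, and "the series" means these few. Any claim that something is new, unique, unknown or untested is made for them only; others in the source may bear on it.

For the measured compounds named here, compound 1 `COCOc1cc(/C=C/C(=O)OCC(=O)Nc2ccc(OC)cc2)ccc1OCc1ccccc1` is the one compound in this set with a measured number: in a functional assay on BEL-7404 cells (Homo sapiens) for cytotoxicity, read by MTT assay, with a stated time of 72 h (a higher number here means a weaker inhibitor, a lower number a stronger inhibitor), compound 1 gives 133000 nM. Compound 2 `COCOc1ccc(/C=C/C(=O)N2CCN(Cc3ccc(Cl)c(Cl)c3)CC2)cc1OCOC` reaches only a limit of the assay, given as > 200000 nM. Compound 3 `COc1ccc(NC(=O)COC(=O)/C=C/c2ccc(OCc3ccccc3)c(O)c2)cc1` likewise stops at a limit, recorded as > 200000 nM. Going by the values given here, the only step between measured compounds, an at least 1.5-fold higher number from compound 1 to compound 3 (0.17 log units; that floor lies within the scatter), has one foot on the limit of > 200000 nM in this assay, at which 2 of the 3 values shown sit, and so tells the size of the loss only as a floor.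

Compound 4 `COCOc1cc(/C=C/C(=O)OCC(=O)Nc2nccs2)ccc1OCc1ccccc1` differs from compound 1 on an amide-type nitrogen whose other neighbours are a carbonyl carbon: 1,3-thiazol-2-yl in place of 4-methoxyphenyl on an amide-type nitrogen. Among the compounds with values here, no measured step touches that position; the change in compound 3 is at an oxygen on an aromatic ring, so nothing here sets a size or a direction for this swap. The expectation is a step of a 1.1-fold higher number from compound 1 to compound 4 (0.05 log units; within the scatter), no larger than the scatter. Compound 4 is therefore estimated at 150000 nM, with a range from 60000 nM to 400000 nM, while two of the three measured compounds returning only a limit leaves a real chance of another limit.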

Compound 4, half-maximal inhibitory concentration: 130000 nM
Compound 4: the middle estimate sits 1.2-fold (0.06 log units) above what was measured; the range from low to high includes it.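

Swapping 4-methoxyphenyl for 1,3-thiazol-2-yl on the amide-type nitrogen gives a 1.0-fold lower number from compound 1 to compound 4 (0.01 log units; within the scatter) in this assay. Unlike the earlier step, this one has a measured number at both ends, so it shows a size and not only a floor. On this core, a six-membered aromatic ring of carbon only and a five-membered aromatic ring with 2 hetero atoms therefore read alike at this position, and compound 4 gives a number rather than adding to the compounds that stop at a limit: the limit of > 200000 nM in this assay, at which 2 of the 4 values shown sit.

From the compounds shown here alone, both groups compared here are aromatic rings, so it remains open whether a plain methyl group, a pyridine ring or a chain ending in a carboxylic acid would read the same on that nitrogen. One pair also cannot say whether the swap would behave alike on the core of compound 3.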